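This account rests on a few compounds, and the source may have more. Where it says the series, first, only, none or still open, it means among the compounds named here.

Working notes on a series built on a shared core, seen in compound 1 `COc1ccc(C(=O)/C=C/c2cc(OC)c(OC)cc2OC)c(O)c1`, compound 2 `COc1ccc(C(=O)/C=C/c2ccc(C(=O)Nc3cc([N+](=O)[O-])ccc3O)cc2)c(O)c1` and compound 3 `COc1ccc(C(=O)/C=C/c2cc(Br)c(OCc3ccccc3)c(OC)c2)c(O)c1`. The measurement is an ADME assay on SH-SY5Y cells (Homo sapiens) for cytotoxicity, read by MTT assay, with a stated time of 48 h; a lower number here means a stronger inhibitor, a higher number a weaker inhibitor. In this assay compound 1 returns only a limit, > 100000 nM. Compound 2 likewise returns a limit, > 100000 nM. Compound 3 also returns a limit, > 100000 nM. Compound 2 therefore stands exactly where the rest of the measured set stands, namely at the limit of > 100000 nM in this assay, at which 3 of the 3 values shown sit, and no order among the three can be drawn. For the measured compounds named here, no two measured compounds differ in a single place, so no measured step is available.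

Compound 4 `COc1ccc(C(=O)/C=C/c2ccc(C(=O)NC(C)C)cc2)c(O)c1` is not yet measured. It differs from compound 2 by isopropyl in place of 2-hydroxy-5-nitrophenyl on an amide-type nitrogen. Going by the values given here, with no measured step to lean on, and with compound 1, compound 2 and compound 3 all sitting at the limit of > 100000 nM in this assay, at which 3 of the 3 values shown sit, no movement beyond the scatter is expected in this assay in either direction. Compound 4 is thus expected to return a limit as well, estimated around 100000 nM, between 30000 nM and 300000 nM. The step this estimate implies is a number no higher from compound 2 to compound 4 (the limit leaves the size open), expected to be none beyond the scatter.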

Compound 4, half-maximal inhibitory concentration: > 100000 nM
Compound 4: a limit, no number; the forecaster's own chance of this, stated with the estimate: 85%; the middle value lies on the limit itself.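

Compound 2 and compound 4 each return only a limit, not a number, in this assay, so no step between them can be read: the limit of > 100000 nM in this assay, at which 4 of the 4 values shown sit.

The compounds shown leave open whether any of them reaches a readable value in this assay, and how isopropyl and 2-hydroxy-5-nitrophenyl on the amide-type nitrogen compare there.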